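Swapping the Biaryl Substituent on a Bile Acid Receptor Ligand

A few compounds are considered here, and "the series" means these few. Any claim that something is new, unique, unknown or untested is made for them only; others in the source may bear on it.

Compound 2 `COC(=O)/C=C/c1cccc(N(Cc2ccc(-c3cc(Cl)ccc3OC)cc2)C(=O)C(C)C)c1` carries a 5-chloro-2-methoxyphenyl group on the benzylic ring of the shared core. Going by the values given here, in an assay on isolated protein with Bile acid receptor (Homo sapiens) as the target (on this read-out higher numbers stand for an effect only at larger amounts of compound and lower numbers for an effect already at smaller amounts), compound 2 gives 226 nM, the highest of the two numbers measured so far. Among the compounds with values here, its closest neighbour is compound 1 `COC(=O)/C=C/c1cccc(N(Cc2ccc(/C=C/c3cccc(F)c3)cc2)C(=O)C(C)C)c1`, which in this assay gives 71 nM; the only measured step, a 3.2-fold higher number from compound 1 to compound 2 (0.50 log units; beyond the scatter), replaces 2-(3-fluorophenyl)ethenyl with the 5-chloro-2-methoxyphenyl group.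

Compound 3 `COC(=O)/C=C/c1cccc(N(Cc2ccc(-c3ccc(N(C)C)cc3)cc2)C(=O)C(C)C)c1` differs from compound 2 by 4-(dimethylamino)phenyl in place of 5-chloro-2-methoxyphenyl on an aromatic carbon. Within the data shown here, no measured step replaces one six-membered aromatic ring by another at this place, so the single step from compound 1 to compound 2 is the only guide, and it reports what one aryl-type change at this position did. Since that step stayed modest, the change to compound 3 is expected to stay within a comparable span. The number for compound 3 in this assay is therefore estimated at 200 nM, with a range from 60 nM to 700 nM, which would mean an expected step of a 1.1-fold lower number from compound 2 to compound 3 (0.05 log units; within the scatter) from compound 2.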

Compound 3, half-maximal effective concentration: 57 nM
The estimate for compound 3 lay 3.5-fold (0.55 log units) above the measured number; the measured number lies below the stated range.
By their numbers in this assay, from the lowest: compounds 3 and 1 (each within the scatter of the next); then compound 2.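

In this assay, the change from 5-chloro-2-methoxyphenyl to 4-(dimethylamino)phenyl gives a 4.0-fold lower number from compound 2 to compound 3 (0.60 log units; beyond the scatter), even though both groups have the same heavy-atom total, one six-membered aromatic ring of carbon only, no hydrogen-bond donors and one hydrogen-bond acceptor. A ring bound directly at this place is therefore compatible with a number on either side of that step, and these counts alone do not separate compound 2 from compound 3. The replacement of 2-(3-fluorophenyl)ethenyl by 4-(dimethylamino)phenyl gives a 1.2-fold lower number from compound 1 to compound 3 (0.10 log units; within the scatter), which lies within the scatter, so among the three compounds only the 5-chloro-2-methoxyphenyl group stands apart by steps beyond the scatter, and nothing available here accounts for that difference.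

Because each step exchanges a whole substituent, the compounds shown leave open whether a plain phenyl or a 4-methoxyphenyl group at this place would give a number nearer that of compound 2 or those of compound 1 and compound 3. They also leave open whether the same ordering would hold with a carboxylic acid in place of the methyl ester on the shared core.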